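Chloro on the phenyl of compound 3

A few compounds are considered here, and "the series" means these few. Any claim that something is new, unique, unknown or untested is made for them only; others in the source may bear on it.

Compound 3 `O=S(=O)(Nc1ccc(F)c(C#Cc2cnc3[nH]nc(-c4ccccc4)c3c2)c1F)c1cccnc1` gives 200 nM in a functional assay on COLO 205 cells (Homo sapiens) for antiproliferative activity, read by MTT assay, with a stated time of 68 h (on this read-out higher numbers stand for weaker inhibition and lower numbers for stronger inhibition), the highest number of the three measured. Compound 1 `COc1n[nH]c2ncc(C#Cc3c(F)ccc(NS(=O)(=O)c4cccnc4)c3F)cc12` gives 89 nM, compound 2 `O=S(=O)(Nc1ccc(F)c(C#Cc2cnc3[nH]nc(C4CC4)c3c2)c1F)c1cccnc1` gives 61 nM; the steps of a 2.2-fold higher number from compound 1 to compound 3 (0.35 log units; beyond the scatter) and a 3.3-fold higher number from compound 2 to compound 3 (0.52 log units; beyond the scatter) are both beyond the scatter, while a 1.5-fold lower number from compound 1 to compound 2 (0.16 log units; within the scatter) is within it. Compound 4 `O=S(=O)(Nc1ccc(F)c(C#Cc2cnc3[nH]nc(-c4cccc(Cl)c4)c3c2)c1F)c1cccnc1` differs from compound 3 by chloro in place of hydrogen on an aromatic carbon on the phenyl ring. For the measured compounds named here, no measured step varies a substituent on that ring; the steps available only exchange the whole group, so they give no direction for this change. The expected step of no change at the digits printed from compound 3 to compound 4 (within the scatter) is therefore none beyond the scatter. Compound 4 is estimated at 200 nM in this assay, with a range from 70 nM to 600 nM.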

Compound 4, half-maximal inhibitory concentration: > 10000 nM
Compound 4: no number, only a limit; the forecaster's own chance of this, stated with the estimate: 2%; at least 50-fold (1.69 log units) between middle value and limit.
By their numbers in this assay, from the lowest: compounds 2 and 1 (each within the scatter of the next); then compound 3. At a limit, above all of these: compound 4.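

In this assay compound 4 stands only as a limit of the assay, > 10000 nM. At this place on the phenyl ring, meta to a large group, a single chloro brings an at least 50-fold higher number from compound 3 to compound 4 (1.69 log units; beyond the scatter), a far larger change than the exchanges of the whole group among compounds 1, 2 and 3 gave. The 3-chlorophenyl group also separates sharply from the other two groups, with an at least 110-fold higher number from compound 1 to compound 4 (2.05 log units; beyond the scatter) and an at least 160-fold higher number from compound 2 to compound 4 (2.21 log units; beyond the scatter).

Still open, on these data alone, is whether a methyl, a fluoro or an amine at this place would behave as chloro does. Also open, as far as these compounds go, is whether the change follows chloro itself or its place on the ring.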